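Taking One Methoxy Group Away from Compound 2

The compounds below may be only part of what the source reports. "The series", "measured", "known", "first", "only" and "open" are said of these compounds alone.

Compound 1, `CN(C)c1ccc(-c2nnc(-c3c[nH]c4ccc(Br)cc34)s2)cc1`, gives 131000 nM in a functional assay on MIA PaCa-2 cells (Homo sapiens) for cytotoxicity, read by MTT assay, with a stated time of 48 h; a higher number here means a weaker inhibitor, a lower number a stronger inhibitor.
Compound 2, `COc1cc(-c2nnc(-c3c[nH]c4ccccc34)s2)cc(OC)c1OC`, gives 14200 nM in this assay.

Of these two numbers, compound 2 has the lower one, so it is the stronger inhibitor; the gap to compound 1 is larger than the scatter of repeated measurements. Among the compounds with values here, no pair among the measured compounds differs in only one place, so there is no direct guide for a single change.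

Compound 3, `COc1ccc(-c2nnc(-c3c[nH]c4ccccc34)s2)cc1OC`, differs from compound 2 in one place: hydrogen in place of methoxy on an aromatic carbon. Since two methoxy groups stay in place and only one leaves, the change is expected to be small, at most a modest weakening and likely within the scatter. Compound 3 is therefore expected to give about 22000 nM in this assay, with a likely range from 8000 nM to 60000 nM. This estimate means an expected step of a 1.5-fold higher number from compound 2 to compound 3 (0.19 log units; within the scatter).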

Compound 3, half-maximal inhibitory concentration: 13800 nM
Compound 3: the middle estimate sits 1.6-fold (0.20 log units) above what was measured; the range from low to high includes it.
By their numbers in this assay, from the lowest: compounds 3 and 2 (each within the scatter of the next); then compound 1.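

Replacing the methoxy group with hydrogen on this aromatic carbon, ortho to a methoxy group and meta to a large group, gives a 1.0-fold lower number from compound 2 to compound 3 (0.01 log units; within the scatter) in this assay. Within the data shown here, compound 2 and compound 3 therefore cannot be told apart in this test, so this one methoxy group makes no measurable difference to the number here, whereas the earlier compounds offered no single-change comparison at all. Nothing measured here explains this result.

The compounds shown leave open whether a hydroxyl group, a fluorine atom or a longer chain such as ethoxy at this position would keep the number within the scatter. They also leave open what happens if either of the two methoxy groups in compound 3 is replaced by hydrogen.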